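A fluoro on the phenyl: the step to compound 3

The source may report more compounds than this note shows. Statements on the series, on what has been measured and on what is new or still open speak of the compounds shown alone.

Compound 1 `CNCc1cc(-c2ccccc2)n(S(=O)(=O)c2ccccc2)c1`: 96%
Compound 2 `CNCc1cc(-c2cccnc2F)n(S(=O)(=O)c2ccccc2)c1`: 99%
Compound 3 `CNCc1cc(-c2cccnc2F)n(S(=O)(=O)c2cccc(F)c2)c1`: not yet measured

For the measured compounds named here, in a functional assay on the whole organism (strain Jcl:SD) for inhibition, with Rattus norvegicus as the target, with stated times of 3 min and 3 h, at a dose of 1 mg/kg by the intravenous route (a lower number here means less inhibition, a higher number more inhibition at the dose given (going by the name of the read-out)), compound 2 gives 99%, the higher of the two numbers known so far. Compound 1 gives 96%, and the step of a number 3 percentage points higher from compound 1 to compound 2 (within the scatter) lies within the scatter, so the two compounds are not distinguished by this read-out. Compound 3 differs from compound 2 by fluoro in place of hydrogen on an aromatic carbon. Going by the values given here, no measured step touches that phenyl; the one step that is known, from compound 1 to compound 2, changes a different part of the molecule and stays within the scatter. Both measured numbers already sit near the top of the range of the read-out. Compound 3 is therefore expected to show a step of a number 2 percentage points lower from compound 2 to compound 3 (within the scatter), that is, none beyond the scatter. The estimate for compound 3 is 97%, with a range from 88% to 100%.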

Compound 3, a percentage reported as inhibition, in the whole organism at one dose (the size of the read-out at that dose, not a potency): 99%
Beside the measured number, compound 3's estimate is 2 percentage points below it; measured number inside the range.
By their numbers in this assay, from the lowest: compounds 1, 2 and 3 (each within the scatter of the next).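

In this assay, for the compounds shown here, the first measured change on this ring, phenyl to 3-fluorophenyl, meta to a large group, gives no change at the digits printed from compound 2 to compound 3 (within the scatter). The ring therefore carries a fluoro at this position with the read-out still close to the top of its range, where compound 3 gives 99%, so a gain from this change could hardly show at this single dose. Nothing measured here offers an explanation for this result.
The compounds shown leave open whether a chloro, a methoxy, an amine or a carboxylic acid at this position would keep the read-out as high, and what fluoro does at the other carbons of this ring. They also leave open whether the three compounds differ at all, since each stands within the scatter of the next at this one dose.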